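Fluoro to trifluoromethyl on the sulfonyl aryl ring

The source may hold more compounds than are shown below. What is called first, only, known or untested is meant among the compounds shown, and "the series" means these compounds.

Compound 1, `CC(CS(=O)(=O)c1ccc(F)cc1)C(=O)Nc1ccc([N+](=O)[O-])c(C(F)(F)F)c1`: 2670 nM
Compound 2, `CC(CS(=O)(=O)c1ccc(C(F)(F)F)cc1)C(=O)Nc1ccc([N+](=O)[O-])c(C(F)(F)F)c1`: 3310 nM
Compound 3, `CC(CS(=O)(=O)c1ccc(F)cc1)C(=O)Nc1ccc([N+](=O)[O-])cc1C(F)(F)F`: 4050 nM

These three compounds were tested in a functional assay on LNCaP cells (Homo sapiens) for antiproliferative activity, read by MTT assay, with a stated time of 96 h; on this read-out higher numbers stand for weaker inhibition and lower numbers for stronger inhibition. Compound 1 and compound 3 are built from the same atoms joined differently; the difference between the two cores is not broken down here. Compound 2 differs from compound 1 by trifluoromethyl in place of fluoro on an aromatic carbon, and this change gave a 1.2-fold higher number from compound 1 to compound 2 (0.09 log units; within the scatter). Compound 4, `CC(CS(=O)(=O)c1ccc(C(F)(F)F)cc1)C(=O)Nc1ccc([N+](=O)[O-])cc1C(F)(F)F`, has not yet been measured in this assay; it differs from compound 3 by trifluoromethyl in place of fluoro on an aromatic carbon, the same change as that from compound 1 to compound 2, since both place descriptions agree word for word. Because the earlier change gave a 1.2-fold higher number from compound 1 to compound 2 (0.09 log units; within the scatter), a step of similar size, a 1.2-fold higher number from compound 3 to compound 4 (0.08 log units; within the scatter), is expected here. Compound 4 is therefore estimated at 4900 nM, with a plausible range from 2500 nM to 9500 nM.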

Compound 4, half-maximal inhibitory concentration: 26300 nM
For compound 4 the middle estimate is 5.4-fold (0.73 log units) below the measured one; measured number above the stated range.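

In this assay, trifluoromethyl in place of fluoro gave a 6.5-fold higher number from compound 3 to compound 4 (0.81 log units; beyond the scatter), and the two steps measured for this change do not agree: the same change on two cores in this assay, a 1.2-fold higher number (0.09 log units; within the scatter) from compound 1 to compound 2 and a 6.5-fold higher number (0.81 log units; beyond the scatter) from compound 3 to compound 4, 5.2-fold (0.72 log units) apart, beyond the scatter of two such steps In this series, then, the size of the step depends on the core that carries it, and the small step seen on the core of compound 1 could not be carried over to the core of compound 3. With only these two pairs, the data do not show which feature of the cores is responsible, nor do they give a rule for any further core.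

The compounds shown leave open how a chloro or a nitrile in the place of fluoro would behave on these two cores. They also leave open whether a nitrile in the place of the nitro group would alter the gap between the two steps.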